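Compound 2: a second aromatic ring in place of phenoxy

This account rests on a few compounds, and the source may have more. Where it says the series, first, only, none or still open, it means among the compounds named here.

Compounds measured in a functional assay on PC-3 cells (Homo sapiens) for antiproliferative activity, read by MTT assay, with a stated time of 48 h; on this read-out higher numbers stand for weaker inhibition and lower numbers for stronger inhibition:
compound 1 `COc1ccc(CN(C(=O)Cn2cc(COc3ccc4ccc(=O)oc4c3)nn2)c2cc(OC)c(OC)c(OC)c2)cc1` gives 860 nM
compound 2 `COc1ccc(CN(C(=O)Cn2cc(COc3ccccc3)nn2)c2cc(OC)c(OC)c(OC)c2)cc1` gives 45300 nM

Within the data shown here, compound 2 stands at the higher of the two numbers so far, with compound 1 well below it. The next member, compound 3 `COc1ccc(CN(C(=O)Cn2cc(CSc3nc4ccccc4s3)nn2)c2cc(OC)c(OC)c(OC)c2)cc1`, differs from compound 2 as follows: (1,3-benzothiazol-2-yl)sulfanyl in place of phenoxy on a saturated chain carbon bound to an aromatic carbon. In words, (1,3-benzothiazol-2-yl)sulfanyl takes the place of phenoxy on a saturated chain carbon bound to an aromatic carbon. Among the measured compounds shown here, only one measured step bears on this, and only indirectly: a 53-fold higher number from compound 1 to compound 2 (1.72 log units; beyond the scatter), large and beyond the scatter, where the group on the oxygen goes from two aromatic rings to one. For the measured compounds named here, compound 3 also carries two aromatic rings, but different ones, attached through sulfanyl, and no measured compound covers that change. Resting on a 53-fold higher number from compound 1 to compound 2 (1.72 log units; beyond the scatter), the expectation is a lower number, with the size of the step less certain: the estimated step is a 15-fold lower number from compound 2 to compound 3 (1.18 log units; beyond the scatter). The expected value for compound 3 is 3000 nM with an estimated range from 600 nM to 15000 nM.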

Compound 3, half-maximal inhibitory concentration: 28500 nM
Beside the measured number, compound 3's estimate is 9.5-fold (0.98 log units) below it; measured number above the stated range.
By their numbers in this assay, from the lowest: compound 1; then compounds 3 and 2 (each within the scatter of the next).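

In this assay, two aromatic rings at this place do not on their own give a low number: (1,3-benzothiazol-2-yl)sulfanyl in place of phenoxy gives a 1.6-fold lower number from compound 2 to compound 3 (0.20 log units; within the scatter), which leaves the two groups indistinguishable on this read-out. Compound 1 remains apart, with a 33-fold higher number from compound 1 to compound 3 (1.52 log units; beyond the scatter), so among these three compounds the low number goes with the particular group of compound 1 and not with ring count alone. Nothing available explains this difference.

This change replaces the ring system and the linking oxygen with sulfur in a single step, and the compounds shown do not separate the two. Going by these compounds, how (1,3-benzothiazol-2-yl)oxy, an amine or a carboxylic acid would read on a saturated chain carbon bound to an aromatic carbon remains open.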